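The compounds below may be only part of what the source reports. "The series", "measured", "known", "first", "only" and "open" are said of these compounds alone.

Measured so far in an ADME assay on the whole organism (Rattus norvegicus, strain Sprague-Dawley) for pharmacokinetics, with a stated time of 6 h, at a dose of 10 mg/kg by the oral route; on this read-out lower numbers stand for lower exposure and higher numbers for higher exposure at the dose given:
compound 1 `Cc1cn2cc(-c3cc4ccc(N5CCN(C)CC5)cc4oc3=O)nc2c(C)n1` gives 530 ng.h/mL
compound 2 `CCN1CCN(c2ccc3cc(-c4cn5cc(C)nc(C)c5n4)c(=O)oc3c2)C[C@@H]1C` gives 1100 ng.h/mL
compound 3 `Cc1cn2cc(-c3cc4ccc(N5CCNCC5)cc4oc3=O)nc2c(C)n1` gives 340 ng.h/mL

Compound 3 stands at the lowest of the three numbers in this assay. Against compound 1 the gap is a 1.6-fold lower number from compound 1 to compound 3 (0.19 log units; within the scatter), which is within the scatter, so no order between the two can be read; against compound 2 the gap is a 3.2-fold lower number from compound 2 to compound 3 (0.51 log units; beyond the scatter), beyond the scatter. Compound 4 `Cc1cn2cc(-c3cc4ccc(N5CCN(C)[C@@H](C)C5)cc4oc3=O)nc2c(C)n1` has not been measured yet. The change from compound 3 is 3,4-dimethylpiperazin-1-yl in place of piperazin-1-yl on an aromatic carbon. For the measured compounds named here, three measured steps bear on it. Reversal of a 1.6-fold lower number from compound 1 to compound 3 (0.19 log units; within the scatter) would put the methyl back on the ring nitrogen, a move that by itself stayed within the scatter. The step of a 3.2-fold lower number from compound 2 to compound 3 (0.51 log units; beyond the scatter) runs in the opposite sense to the present change and was beyond the scatter, and a 2.1-fold higher number from compound 1 to compound 2 (0.32 log units; beyond the scatter) points the same way when alkyl groups are added to the piperazine ring. Compound 4 sits between compound 1 and compound 2 in substitution, so the step expected is a 2.1-fold higher number from compound 3 to compound 4 (0.31 log units; beyond the scatter), upward and modest. The estimate for compound 4 is 700 ng.h/mL, with a range from 350 ng.h/mL to 1400 ng.h/mL.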

Compound 4, area under the concentration-time curve: 260 ng.h/mL
Beside the measured number, compound 4's estimate is 2.7-fold (0.43 log units) above it, and the stated range ends above it.
By their numbers in this assay, from the lowest: compounds 4, 3 and 1 (each within the scatter of the next, the first and the last beyond it); then compound 2.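

On the aromatic carbon of the shared core, more alkyl on the piperazine does not by itself raise the number in this assay: 3,4-dimethylpiperazin-1-yl against piperazin-1-yl gives no readable order (a 1.3-fold lower number from compound 3 to compound 4 (0.12 log units; within the scatter)). Against 4-methylpiperazin-1-yl, the added ring methyl goes downward (a 2.0-fold lower number from compound 1 to compound 4 (0.31 log units; beyond the scatter)), and compound 2 goes against any reading that added alkyl lowers the number. Ethyl in place of methyl separates compound 2 from compound 4 (a 4.2-fold lower number from compound 2 to compound 4 (0.63 log units; beyond the scatter)), so among these compounds the higher number of compound 2 goes with the ethyl group, not with the ring methyl alone.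

No measurement at hand gives a reason for these steps. Open, going by these compounds, are whether 4-ethylpiperazin-1-yl without the ring methyl holds the higher number, and how a longer chain such as propyl or a morpholin-4-yl group would compare.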